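Cytotoxicity of a Fluoromethyl Cyclohexyl Amide Analogue

The source may report more compounds than this note shows. Statements on the series, on what has been measured and on what is new or still open speak of the compounds shown alone.

compound 1 `CC(C)N(c1cc(C#CC(C)(C)C)sc1C(=O)O)C(=O)[C@H]1CC[C@H](C)CC1` — in an ADME assay on MT4 cells (Homo sapiens) for cytotoxicity, with a stated time of 5 days (a higher number here means that more compound is tolerated, a lower number that less compound is tolerated), compound 1 gives > 20000 nM
compound 2 `CC(C)N(c1cc(C#CC(C)(C)C)sc1C(=O)O)C(=O)[C@H]1CC[C@H](Cl)CC1` — in this assay compound 2 gives > 20000 nM
compound 3 `CC(C)N(C(=O)[C@@H]1CC[C@@H]2C[C@@H]2CC1)c1cc(C#CC(C)(C)C)sc1C(=O)O` — in this assay compound 3 gives > 20000 nM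

Each of these three values is a limit of the assay, not a number, as the limit of > 20000 nM in this assay, at which 3 of the 3 values shown sit, records. Within the data shown here, compound 3 thus stands at the same limit as its two companions, and no compound among the three can be ranked against another.

Compound 4 `CC(C)N(c1cc(C#CC(C)(C)C)sc1C(=O)O)C(=O)[C@H]1CC[C@H](CF)CC1` is not yet measured. It differs from compound 3 in one place: a group of 8 heavy atoms (7 carbon, 1 fluorine; one six-membered non-aromatic ring of carbon only) in place of a group of 8 heavy atoms (8 carbon; one three-membered non-aromatic ring of carbon only, one seven-membered non-aromatic ring of carbon only), on a carbonyl carbon. Among the measured compounds shown here, the steps that bear on this position are the two that swap the group on the carbonyl carbon, a step that the two limits leave unreadable from compound 1 to compound 3 and a step that the two limits leave unreadable from compound 2 to compound 3, together with the step on the saturated ring carbon, a step that the two limits leave unreadable from compound 1 to compound 2. All three are unreadable, because every value sits at the limit given in the limit of > 20000 nM in this assay, at which 3 of the 3 values shown sit. Nothing in the data shows any of these changes lowering the tolerated concentration, so no step beyond the scatter is expected for a step that the limit leaves unreadable from compound 3 to compound 4. Compound 4 is therefore expected to give about 25000 nM, within the range 10000 nM to 60000 nM, most likely again reported only as a limit.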

Compound 4, half-maximal cytotoxic concentration: > 20000 nM
Compound 4 ended at the assay's limit (the forecaster's own chance of this, stated with the estimate: 85%); the middle value lies beyond the limit too.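

Compound 4 joins compound 1, compound 2 and compound 3 at a limit of the assay, so no step among these four compounds can be read: the limit of > 20000 nM in this assay, at which 4 of the 4 values shown sit.

The compounds shown leave open whether the groups on the carbonyl carbon differ at all in this assay.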